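Shared core series: measured values so far sit at the limit

The compounds below may be only part of what the source reports. "The series", "measured", "known", "first", "only" and "open" are said of these compounds alone.

Measured compounds, in a functional assay on PC-3 cells (Homo sapiens) for antiproliferative activity, read by MTT assay, with a stated time of 24 h; a lower number here means a stronger inhibitor, a higher number a weaker inhibitor:
Compound 1 `c1ccc(-c2noc(-c3ccncc3)n2)cc1` gives > 1000000 nM, a limit of the assay.
Compound 2 `COc1cc(-c2noc(-c3ccncc3)n2)ccc1OCc1ccccc1` gives > 1000000 nM, a limit of the assay.
Compound 3 `COc1ccc(-c2noc(-c3ccc(Cl)cc3)n2)cc1OC1CCCC1` gives > 1000000 nM, a limit of the assay.

Compound 3 therefore stands on a limit rather than a number, and the same holds for the other two values shown: the limit of > 1000000 nM in this assay, at which 3 of the 3 values shown sit. Among the compounds with values here, no step between two measured compounds exists within this set, so nothing about the size of a change can be read from the measured compounds themselves.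

Compound 4 `COc1ccc(-c2noc(-c3ccncc3)n2)cc1OC1CCCC1` is not yet measured in this assay. It differs from compound 3 in one place: pyridin-4-yl in place of 4-chlorophenyl on an aromatic carbon. Compound 1 carries the pyridin-4-yl group and sits at the limit. Compound 2 carries it too and also sits at the limit. The step expected in this assay is a number no higher from compound 3 to compound 4 (the limit leaves the size open), that is, none beyond the scatter, most likely ending in another limit. Compound 4 is expected at 1000000 nM, with a range from 300000 nM to 3000000 nM in this assay.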

Compound 4, half-maximal inhibitory concentration: > 1000000 nM
Compound 4: a limit, no number; the forecaster's own chance of this, stated with the estimate: 85%; the middle value sits exactly at the limit.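

In this assay, within the data shown here, compound 3 and compound 4 both stand on a limit, and no step between them can be read: the limit of > 1000000 nM in this assay, at which 4 of the 4 values shown sit. The compounds shown leave open whether any change on the shared core gives a number in this assay rather than a limit.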